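The compounds below may be only part of what the source reports. "The series", "measured", "known", "first", "only" and "open" are said of these compounds alone.

In a functional assay on SW-620 cells (Homo sapiens) for cytotoxicity, read by MTT assay, with a stated time of 3 days (on this read-out higher numbers stand for an effect only at larger amounts of compound and lower numbers for an effect already at smaller amounts), three compounds on a shared core have been measured. Compound 1 `O=C1/C(=C/c2ccc(Cl)cc2)c2ccccc2N1c1c(Cl)cccc1Cl` gives 100 ug/mL. Compound 2 `O=C1/C(=C/c2c(Cl)cccc2Cl)c2ccccc2N1c1c(Cl)cccc1Cl` reports only a limit, > 100 ug/mL. Compound 3 `COc1ccc(/C=C2/C(=O)N(c3c(Cl)cccc3Cl)c3ccccc32)cc1` also reports only a limit, > 100 ug/mL. Most of this small set therefore stands at one value: the limit of > 100 ug/mL in this assay, at which 2 of the 3 values shown sit.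

Compound 4 `CN(C)c1ccc(/C=C2/C(=O)N(c3c(Cl)cccc3Cl)c3ccccc32)cc1` has not yet been measured. It differs from compound 3 by dimethylamino in place of methoxy on an aromatic carbon, with dimethylamino in place of methoxy on an aromatic carbon, para to a large group. The step bearing most directly on this position is a number no lower from compound 1 to compound 3 (the limit leaves the size open), and a number no lower from compound 1 to compound 2 (the limit leaves the size open) also changes the same aryl group. Neither has a readable size, and a step that the two limits leave unreadable from compound 2 to compound 3 cannot be read either. Going by the values given here, no measured step therefore predicts a shift, so none beyond the scatter is expected in this assay. The expected step is a number no higher from compound 3 to compound 4 (the limit leaves the size open). For compound 4 the estimated value is 100 ug/mL, with an expected range from 30 ug/mL to 200 ug/mL.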

Compound 4, concentration for half-maximal effect: > 100 ug/mL
Compound 4 ended at the assay's limit; the forecaster's own chance of this, stated with the estimate: 60%; the middle value sits exactly at the limit.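

In this assay compound 4 gives > 100 ug/mL, which is a limit of the assay and not a number. Dimethylamino on this aromatic carbon, para to a large group, thus stays at that limit just as methoxy does, and the set gathers further at one value: the limit of > 100 ug/mL in this assay, at which 3 of the 4 values shown sit. Dimethylamino in place of chloro on this aromatic carbon gives a number no lower from compound 1 to compound 4 (the limit leaves the size open) and so shows a direction only. The other new steps cannot be read, so the change from methoxy to dimethylamino has no size that can be stated.

Compound 1, with chloro on that carbon, remains the only one of the four with a plain number, 100 ug/mL. From the compounds shown here alone, whether a nitrile or a carboxylic acid on the same carbon would give a readable value in this assay stays open, as does any difference among the compounds that sit at the limit.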